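A few compounds are considered here, and "the series" means these few. Any claim that something is new, unique, unknown or untested is made for them only; others in the source may bear on it.

Compound 1 `CCC1(CCCCN2CCN(c3cccc(Cl)c3)CC2)C(=O)Nc2ccccc21` was examined in a functional assay on the whole organism (strain NMRI) with Mus musculus as the target, with a stated time of 5 min; a lower number here means that less compound is needed, a higher number that more compound is needed for the effect. In this assay compound 1 gives only a limit, > 10 mg/kg. Compound 3 `O=C1Nc2ccccc2C1CCCCN1CCN(c2cccc(Cl)c2)CC1`, which carries hydrogen in place of ethyl on a saturated ring carbon, likewise gives only a limit in this assay, > 10 mg/kg. The step that the two limits leave unreadable from compound 1 to compound 3 therefore cannot be read. Compound 2 `CCC1(CCCCN2CCN(c3cccc(Cl)c3)CC2)C(=O)Nc2ccc(Cl)cc21` has no result in this assay, "not determined" (no result reported). Compound 1 thus stands at the limit of > 10 mg/kg in this assay, at which 2 of the 3 values shown sit, and no measured step sizes any part of the structure. Compound 4 `CCC1(CCCCN2CCN(c3ccc(F)cc3)CC2)C(=O)Nc2ccccc21` differs from compound 1 by 4-fluorophenyl in place of 3-chlorophenyl on an amine nitrogen in a ring. Among the measured compounds shown here, no measured step bears on this change, so no direction can be drawn. Compound 4 is accordingly expected at 10 mg/kg, between 3 mg/kg and 30 mg/kg, with the step of a number no higher from compound 1 to compound 4 (the limit leaves the size open) estimated as none beyond the scatter.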

Compound 4, minimum effective dose: < 1 mg/kg
Compound 4: no number, only a limit (the forecaster's own chance of this, stated with the estimate: 55%); at least 10-fold (1.00 log units) between middle value and limit.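

In this assay, 4-fluorophenyl in place of 3-chlorophenyl on an amine nitrogen in a ring gives the first readable step among these compounds: an at least 10-fold lower number from compound 1 to compound 4 (1.00 log units; beyond the scatter). This position therefore affects the dose needed, whereas the ethyl change could not be read. Compound 4 alone holds the low limit: the limit of < 1 mg/kg in this assay, at which 1 of the 4 values shown sits.

Whether the change of halogen or its location on the phenyl ring carries the step stays open, since 4-chlorophenyl and 3-fluorophenyl are not among the compounds shown. Also open, as far as these compounds go, is whether 4-fluorophenyl acts alike with hydrogen in place of ethyl on a saturated ring carbon.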